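Swapping a Fluoro for a Methyl on the Aryl Ring

A few compounds are considered here, and "the series" means these few. Any claim that something is new, unique, unknown or untested is made for them only; others in the source may bear on it.

Compound 1 `COc1ccccc1N1C(=O)C(C)SC1c1cccc(C(=O)NCCCCc2ccccc2)c1` and compound 2 `O=C(NCCCCc1ccccc1)c1cccc(C2SCC(=O)N2c2cccc(F)c2)c1` were measured in a functional assay on MG-63 cells (Homo sapiens) for inhibition, read by CCK-8 assay, with a stated time of 72 h, tested at 1 uM; a higher number here means more inhibition at the concentration tested (going by the name of the read-out), a lower number less inhibition. There compound 1 gives 94% and compound 2 gives 92%, so compound 2 has the lowest of the two numbers, yet its gap to compound 1 lies within the scatter. Compound 3 `Cc1cccc(N2C(=O)CSC2c2cccc(C(=O)NCCCCc3ccccc3)c2)c1` is not yet measured. It differs from compound 2 by methyl in place of fluoro on an aromatic carbon. Among the measured compounds shown here, no step between measured compounds is available, so little change beyond the scatter is expected, and for compound 3 the expected step is a number 2 percentage points lower from compound 2 to compound 3 (within the scatter). Compound 3 is estimated at 90%, between 75% and 98%.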

Compound 3, a percentage reported as inhibition, at one concentration (the size of the read-out at that concentration, not a potency): 93%
For compound 3 the middle estimate is 3 percentage points below the measured one; the range from low to high includes it.
By their numbers in this assay, from the lowest: compounds 2, 3 and 1 (each within the scatter of the next).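

In this assay, among the compounds shown here, the change from 3-fluorophenyl to 3-methylphenyl gives a number 1 percentage points higher from compound 2 to compound 3 (within the scatter), the first step here that changes only one place in the molecule. At this position on the aromatic ring, fluoro and methyl therefore cannot be told apart at the single concentration tested.

Going by these compounds, whether an amine or a carboxylic acid on this same carbon would keep the inhibition remains open, as does whether fluoro and methyl would still match at lower concentrations. No measurement shown here explains why the two groups match.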